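Replacing the phenoxy of compound 1 with a piperidinyl ether

The source may hold more compounds than are shown below. What is called first, only, known or untested is meant among the compounds shown, and "the series" means these compounds.

Measured compounds:
- compound 1, `CCS(=O)(=O)Nc1ccc(Oc2ccccc2)c(-c2cn(C)c(=O)c3[nH]ccc23)c1`: < 45 mL/min/kg
- compound 2, `Cn1cc(-c2cc(S(N)(=O)=O)ccc2Oc2ccccc2)c2cc[nH]c2c1=O`: < 43.4 mL/min/kg
- compound 3, `Cn1cc(-c2cc(NS(C)(=O)=O)ccc2Oc2ccccc2C(F)(F)F)c2cc[nH]c2c1=O`: 533 mL/min/kg

In an ADME assay on microsomes from liver (Homo sapiens) for metabolic stability, read by HPLC, using NADPH, with stated times of 5 min and 60 min, tested at 10 uM (a higher number here means faster removal of the compound, a lower number slower removal), compound 1 returns only a limit, < 45 mL/min/kg. Compound 2 likewise returns only a limit in this assay, < 43.4 mL/min/kg. Compound 3 gives a number in this assay, 533 mL/min/kg. So compound 1 stands among the two compounds whose clearance is known only as a limit, and the step that the two limits leave unreadable from compound 1 to compound 2 cannot be read in size, because both ends sit at limits (the limit of < 45 mL/min/kg in this assay, at which 1 of the 3 values shown sits, and (the limit of < 43.4 mL/min/kg in this assay, at which 1 of the 3 values shown sits)).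

Compound 4, `CCS(=O)(=O)Nc1ccc(OC2CCN(C)CC2)c(-c2cn(C)c(=O)c3[nH]ccc23)c1`, differs from compound 1 by 1-methylpiperidin-4-yl in place of phenyl on an oxygen on an aromatic ring. For the measured compounds named here, no measured step changes this part of the molecule; the two readable facts about the shared core are that compound 1 sits at a limit and compound 2 sits at a limit, while compound 3 carries a different aryl ether and is cleared quickly. On that basis compound 4 is expected to stay near the low end, with a step that the limit leaves unreadable from compound 1 to compound 4, not beyond the usual scatter. Compound 4 is therefore estimated at 30 mL/min/kg, within 10 mL/min/kg to 110 mL/min/kg, with a fair chance that only a limit is reported again.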

Compound 4, clearance: < 28.4 mL/min/kg
Compound 4 gave a limit, no number (the forecaster's own chance of this, stated with the estimate: 50%); middle value at least 1.0-fold (0.02 log units) away from the limit.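

In this assay compound 4 returns < 28.4 mL/min/kg and this is a limit, not a number. For the compounds shown here, compound 1 also stands at a limit, so no step between compound 1 and compound 4 can be read in size. The compounds shown leave open whether (1-methylpiperidin-4-yl)oxy in place of phenoxy changes clearance on the shared core at all, and by how much.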